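Compound 1 to compound 4: a triazole exchange

The source may hold more compounds than are shown below. What is called first, only, known or untested is meant among the compounds shown, and "the series" means these compounds.

Within the data shown here, compound 1 `CC(C)(O/N=C(\C(=O)N[C@@H]1C(=O)N(S(=O)(=O)O)[C@@H]1Cn1cncn1)c1csc(N)n1)C(=O)O` is the reference, and in a physicochemical assay for metabolic stability, read by HPLC and mass spectrometry, in phosphate buffer, at 37 degrees C, at pH 7.4 (on this read-out higher numbers stand for a longer-lived compound and lower numbers for a shorter-lived compound), compound 1 gives 233 h as the only true number in the set. Compound 2 `C[C@@H]1CN(C[C@@H]2[C@H](NC(=O)/C(=N\OC(C)(C)C(=O)O)c3csc(N)n3)C(=O)N2S(=O)(=O)O)C(=O)O1` gives > 37 h as a limit of the assay and not a number. Compound 3 `CC(C)(O/N=C(\C(=O)N[C@@H]1C(=O)N(S(=O)(=O)O)[C@@H]1CN1C[C@H](CN)OC1=O)c1csc(N)n1)C(=O)O` gives > 37 h as a limit as well. Compound 1 therefore cannot be ranked against either of the other two.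

Compound 4 `CC(C)(O/N=C(\C(=O)N[C@@H]1C(=O)N(S(=O)(=O)O)[C@@H]1Cn1cc(CO)nn1)c1csc(N)n1)C(=O)O` keeps the shared core and differs at one place, on a saturated chain carbon bound to a saturated ring carbon: 4-(hydroxymethyl)-1H-1,2,3-triazol-1-yl in place of 1H-1,2,4-triazol-1-yl on a saturated chain carbon bound to a saturated ring carbon in all. There, 4-(hydroxymethyl)-1H-1,2,3-triazol-1-yl takes the place of 1H-1,2,4-triazol-1-yl.

The measured changes at that place are a step that the limit leaves unreadable from compound 1 to compound 2 and a step that the limit leaves unreadable from compound 1 to compound 3 together with a step that the two limits leave unreadable from compound 2 to compound 3 as the third. Because of the limit of > 37 h in this assay, at which 2 of the 3 values shown sit, none of them gives a size.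

The expectation therefore rests on compound 1 at 233 h alone, with no measured effect to carry over. The step expected is a 1.2-fold lower number from compound 1 to compound 4 (0.07 log units; within the scatter) and it stays within the scatter, with no firm direction. For compound 4 the estimated half-life is 200 h with 80 h as the expected lower end and 500 h as the upper end.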

Compound 4, half-life: > 37 h
Compound 4: only a limit was reported; the forecaster's own chance of this, stated with the estimate: 40%; the middle value lies beyond the limit too.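

In this assay compound 4 gives > 37 h, a limit of the assay and not a number. Among these compounds, no step linking compound 4 with compound 1, compound 2 or compound 3 can be read: the limit of > 37 h in this assay, at which 3 of the 4 values shown sit.

The compounds shown leave open how the half-lives of compound 2, compound 3 and compound 4 stand against one another and against compound 1.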